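Fluoro in place of hydrogen on the phenyl ring of compound 2

The source may report more compounds than this note shows. Statements on the series, on what has been measured and on what is new or still open speak of the compounds shown alone.

Among the compounds with values here, in a functional assay on K562 cells (Homo sapiens) for cytotoxicity (on this read-out lower numbers stand for higher toxicity in this test and higher numbers for lower toxicity in this test), compound 2 `Clc1ccc(OC(CCn2ccnc2)c2ccccc2)c(Cl)c1` gives 96700 nM, the higher of the two numbers measured so far; its only neighbour, compound 1 `Cc1ccc(C(CCn2ccnc2)Oc2ccc(Cl)cc2Cl)cc1`, gives 31400 nM. Within the data shown here, the one measured step, a 3.1-fold higher number from compound 1 to compound 2 (0.49 log units; beyond the scatter), is the only comparison that bears on the change now considered. Compound 3 `Fc1ccc(C(CCn2ccnc2)Oc2ccc(Cl)cc2Cl)cc1` puts a substituent back on the carbon that carries the methyl in compound 1, with a different group: fluoro in place of hydrogen on an aromatic carbon. Among the measured compounds shown here, whether a fluoro acts like the methyl that was removed cannot be read from these two compounds; the single step only shows that a group on that carbon gave a modestly lower number. The analogy between fluoro and methyl is loose. The writer therefore expects at most a smaller movement in the same direction in this assay, one that may not clear the scatter. For compound 3 the estimated step is a 1.8-fold lower number from compound 2 to compound 3 (0.25 log units; within the scatter). Compound 3 is therefore expected to give 55000 nM in this assay, with a range from 22000 nM to 130000 nM.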

Compound 3, half-maximal cytotoxic concentration: 33500 nM
Estimate against measurement, compound 3: 1.6-fold (0.22 log units) above; the measured number falls inside the stated range.
By their numbers in this assay, from the lowest: compounds 1 and 3 (each within the scatter of the next); then compound 2.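

In this assay, within the data shown here, the change from phenyl to 4-fluorophenyl gives a 2.9-fold lower number from compound 2 to compound 3 (0.46 log units; beyond the scatter), so a second group on this aromatic carbon, para to a large group, also moves the number down beyond the scatter, where the earlier compounds showed this only for methyl. Exchanging the two groups gives a 1.1-fold higher number from compound 1 to compound 3 (0.03 log units; within the scatter), which lies within the scatter, so this test does not tell fluoro from methyl at this position. Among these three compounds, the one with hydrogen on this carbon, compound 2, therefore stands apart from the two that carry a group there, and nothing available explains this shared shift or why the two groups read alike.

Going by these compounds, what remains open is whether the same shift would appear with a chloro, a methoxy, an amine or a carboxylic acid on this carbon, or whether it is limited to fluoro and methyl. On these data alone, it is also open whether a fluoro at another carbon of the same ring would give a similar number, since all three compounds differ only at this one place.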